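A few compounds are considered here, and "the series" means these few. Any claim that something is new, unique, unknown or untested is made for them only; others in the source may bear on it.

Measured so far, in a functional assay on SW-620 cells (Homo sapiens) for cytotoxicity, read by sulforhodamine B assay, with a stated time of 48 h, tested at 0.1 uM; on this read-out lower numbers stand for a stronger effect and higher numbers for a weaker effect at the one concentration tested:

Compound 1, `COc1cc(-c2cc(/C=C/C(=O)c3ccc(N)cc3)[nH]n2)cc(OC)c1OC`, gives 95%.
Compound 2, `COc1ccc(-c2cc(/C=C/C(=O)c3ccc(N)cc3)[nH]n2)cc1OC`, gives 97%.
Compound 3, `COc1cc(C(=O)/C=C/c2cc(-c3cc(OC)c(OC)c(OC)c3)n[nH]2)cc(OC)c1OC`, gives 97%.

All three numbers sit high and close together. For the measured compounds named here, the one single-point change among the measured compounds is that from compound 1 to compound 2, (hydrogen in place of methoxy on an aromatic carbon); on this read-out it made a number 2 percentage points higher from compound 1 to compound 2 (within the scatter). Compound 3 carries the same trimethoxyphenyl-bearing core as compound 1 but with the two ends of the enone arranged the other way round; the difference between the two cores is not broken down here. Its value is level with compound 2 at the digits shown and within the scatter of compound 1, so nothing separates the three.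

Compound 4, `COc1ccc(-c2cc(/C=C/C(=O)c3cc(OC)c(OC)c(OC)c3)[nH]n2)cc1OC`, has not yet been measured in this assay. It is related to compound 3 by hydrogen in place of methoxy on an aromatic carbon, the same change, at the same kind of place, as that from compound 1 to compound 2. Since that earlier step, a number 2 percentage points higher from compound 1 to compound 2 (within the scatter), stayed within the scatter, the step from compound 3 to compound 4 is expected to be of similar size, a number 1 percentage points higher from compound 3 to compound 4 (within the scatter), with the ceiling of the scale limiting any upward room. Compound 4 is therefore estimated at 98%, expected to fall between 90% and 104%.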

Compound 4, a percentage reported as activity, at one concentration (the size of the read-out at that concentration, not a potency): 96%
The estimate for compound 4 lay 2 percentage points above the measured number; the range from low to high includes it.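

In this assay, hydrogen in place of methoxy on an aromatic carbon gave a number 1 percentage points lower from compound 3 to compound 4 (within the scatter), and on the core of compound 1 the same change gave a number 2 percentage points higher from compound 1 to compound 2 (within the scatter). Set side by side, the two steps do not differ, and their opposite signs carry no weight: the same change on two cores in this assay, a number 2 percentage points higher (within the scatter) from compound 1 to compound 2 and a number 1 percentage points lower (within the scatter) from compound 3 to compound 4, 3 percentage points apart, within the scatter of two such steps.
For the compounds shown here, this shows only that the change leaves the read-out of this assay flat on both cores at the one concentration tested, so no size or direction can be assigned to it, and the absence of a difference does not show that an effect of the same size carries from one core to the other, since neither step rises out of the scatter and compounds 1 to 4 all sit high on the scale.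

Still open, as far as these compounds go, is whether any group on these aromatic rings moves the number clear of the scatter, for instance a hydroxy group or a chlorine atom in place of methoxy, or a carboxylic acid on the ring. Also open, from the compounds shown here alone, is whether the methoxy-to-hydrogen change would separate the two cores at a concentration where the read-out falls well away from the top of the scale.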